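Acylaminophenyl series: chain amine in place of methyl

The compounds below may be only part of what the source reports. "The series", "measured", "known", "first", "only" and "open" are said of these compounds alone.

Measured so far:
- compound 1, `CCC(=O)Nc1ccc(C2=NNC(=O)CC2)cc1`: in a functional assay for inhibition, with Homo sapiens as the target (a higher number here means that more compound is needed for the effect, a lower number that less compound is needed), compound 1 gives 0.64 ug/mL.
- compound 2, `CC(=O)Nc1ccc(C2=NN(C)C(=O)CC2)cc1`: in this assay compound 2 gives > 46.4 ug/mL, which is a limit of the assay and not a number.
- compound 3, `CC1CC(c2ccc(N)cc2)=NNC1=O`: in this assay compound 3 gives 43.8 ug/mL.

Compound 1 holds the lowest of the two numbers measured in this assay. The nearest number, that of compound 3, sits higher by a margin beyond the usual scatter. For compound 2 only a limit is known, (the limit of > 46.4 ug/mL in this assay, at which 1 of the 3 values shown sits), and a limit is all that can be said of it. Among the compounds with values here, compounds 2 and 3 each differ from compound 1 in more than one place, so no single-change step between measured compounds is available.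

Compound 4, `CCN(CC)CC(=O)Nc1ccc(C2=NNC(=O)CC2)cc1`, differs from compound 1 in one place: diethylamino in place of methyl on a saturated chain carbon bound to a carbonyl carbon. Within the data shown here, no measured step bears on this change, and its direction in this assay cannot be read from the compounds at hand. The expectation is a step of modest size toward a higher number, with wide uncertainty around it. Compound 4 is expected to give 2 ug/mL in this assay, within a range from 0.4 ug/mL to 15 ug/mL. The step thus estimated is a 3.1-fold higher number from compound 1 to compound 4 (0.49 log units; beyond the scatter).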

Compound 4, half-maximal effective concentration: about 10 ug/mL
The estimate for compound 4 lay 5.0-fold (0.70 log units) below the measured number; the measured number falls inside the stated range.
By their numbers in this assay, from the lowest: compound 1; then compound 4; then compound 3. At a limit, above all of these: compound 2.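

Working notes on the chain carbon bound to the carbonyl carbon: this is the first place in the series where a single change can be read, and in this assay diethylamino in place of methyl gives a 16-fold higher number from compound 1 to compound 4 (1.19 log units; beyond the scatter). The number therefore depends on what this chain carbon carries: compound 4 gives about 10 ug/mL. Nothing at hand accounts for the size or direction of this step.

With a single step at this place, the amine nitrogen and the added carbons cannot be told apart as the source of the change; dimethylamino, a ring amine such as morpholine, and a plain butyl chain on the same carbon would each bear on that question. Also open, as far as these compounds go, is whether the step depends on the amine at all, since a hydroxyl or a carboxylic acid at this place would show how far the number moves with a group that contains no amine nitrogen.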